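Swapping the ether tail for a formyl ester

A few compounds are considered here, and "the series" means these few. Any claim that something is new, unique, unknown or untested is made for them only; others in the source may bear on it.

Of the compounds shown here, three sharing one core have been tested in a functional assay on the whole organism for inhibition, with Mus musculus as the target, at a dose of 10 mg/kg; on this read-out higher numbers stand for more inhibition at the one dose given (going by the name of the read-out) and lower numbers for less inhibition. Compound 1, `CC(C)OCC1=CS(=O)(=O)c2ccccc2C1=O`, gives 99.2% in this assay. Compound 2, `O=C1C(COCCCl)=CS(=O)(=O)c2ccccc21`, gives 98.1% in this assay, and compound 3, `COCCOCC1=CS(=O)(=O)c2ccccc2C1=O`, gives 98.2% in this assay. The three differ only in the group on an oxygen on a saturated carbon, and the steps between them are all small: a number 1.1 percentage points lower from compound 1 to compound 2 (within the scatter), a number 1 percentage points lower from compound 1 to compound 3 (within the scatter) and a number 0.1 percentage points higher from compound 2 to compound 3 (within the scatter). Compound 3 therefore sits alongside compounds 1 and 2, with every one of these values inside the usual scatter of the others.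

Compound 4, `O=COCC1=CS(=O)(=O)c2ccccc2C1=O`, is the next step from compound 3. The change is formyl in place of 2-methoxyethyl on an oxygen on a saturated carbon. Among the measured compounds shown here, every measured step at this oxygen left the number within the scatter, so the numbers at this oxygen have so far stayed level; yet a formyl group is shorter than any tail tried so far, so no measured step covers it directly. For compound 4 the estimated result is therefore 93%, with a range from 75% to 100%. This means an expected step of a number 5.2 percentage points lower from compound 3 to compound 4 (within the scatter), most likely within the scatter, with the uncertainty leaning toward a lower number.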

Compound 4, a percentage reported as inhibition, in the whole organism at one dose (the size of the read-out at that dose, not a potency): 91.6%
The estimate for compound 4 lay 1.4 percentage points above the measured number, within the range that was stated.
By their numbers in this assay, from the lowest: compounds 4, 2, 3 and 1 (each within the scatter of the next).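

In this assay, this oxygen on a saturated carbon accepts a quite different kind of group: formyl, with 2 heavy atoms and a double bond outside aromatic rings, replaces tails that have none of that double bond. The swap gives a number 6.6 percentage points lower from compound 3 to compound 4 (within the scatter), while the other two comparisons give a number 6.5 percentage points lower from compound 2 to compound 4 (within the scatter) and a number 7.6 percentage points lower from compound 1 to compound 4 (within the scatter). These steps are larger in size than those among the first three compounds, yet each remains within the scatter, so they do not establish a real loss and the numbers at this position remain level across all four groups. Nothing measured here offers an explanation for this flatness.

Going by these compounds, whether a longer chain, a phenyl ring, an amine or a carboxylic acid on this oxygen would carry the number beyond the scatter remains open. With a single dose, the read-out also gives no potency, so these four compounds could still differ at lower doses.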